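Flipping One Stereocentre in a Polyphenolic Nitric Oxide Inhibitor

The source may report more compounds than this note shows. Statements on the series, on what has been measured and on what is new or still open speak of the compounds shown alone.

Of the compounds shown here, three have been measured in a functional assay on J774.1 cells (Mus musculus) for inhibition, read by Griess assay, with a stated time of 48 h; on this read-out lower numbers stand for stronger inhibition and higher numbers for weaker inhibition. Compound 1 `COc1cc(O)c([C@@H](/C=C/C[C@@H](O)CCc2ccc(O)cc2)c2ccc(O)cc2)c(O)c1C(=O)[C@@H]1[C@H](/C=C/c2ccc(O)cc2)C[C@H](CCc2ccc(O)cc2)O[C@H]1c1ccc(O)cc1` gives 39000 nM. Compound 2 `COc1cc(O)c([C@@H](/C=C/C[C@@H](O)CCc2ccc(O)cc2)c2ccc(O)cc2)c(O)c1C(=O)/C=C/c1ccc(O)cc1` shares the left-hand part of compound 1 but carries a shorter right-hand portion. In this assay compound 2 gives 39000 nM; at the digits shown this is the same number as compound 1, so the two cannot be told apart within the scatter. Compound 3 `COc1cc(/C=C/C(=O)CC(=O)CCc2ccc(O)c(OC)c2)ccc1O`, a much smaller molecule, gives 181000 nM, a weaker result that lies beyond the scatter relative to compound 1. Together, compound 1 and compound 2 stand at the lowest number of the three.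

Compound 4 `COc1cc(O)c([C@H](/C=C/C[C@@H](O)CCc2ccc(O)cc2)c2ccc(O)cc2)c(O)c1C(=O)[C@@H]1[C@H](/C=C/c2ccc(O)cc2)C[C@H](CCc2ccc(O)cc2)O[C@H]1c1ccc(O)cc1` has not yet been measured. Its relation to compound 1 is the two compounds have the same atoms and bonds and differ only in configuration as drawn: 1 of 8 stereo elements differ; a stereocentre at a saturated chain carbon is drawn S in compound 1 and R in compound 4. Among the measured compounds shown here, no step between two measured compounds of this set probes such a change, so there is no direct precedent here. With every atom and bond retained, the expected step from compound 1 to compound 4 in this assay is none beyond the scatter, no change at the digits printed from compound 1 to compound 4 (within the scatter). Compound 4 is therefore estimated at 39000 nM, within a range from 15000 nM to 100000 nM.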

Compound 4, half-maximal inhibitory concentration: 36000 nM
For compound 4 the middle estimate is 1.1-fold (0.03 log units) above the measured one; low and high end bracket the measured number.
By their numbers in this assay, from the lowest: compounds 4, 1 and 2 (each within the scatter of the next); then compound 3.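

Among the compounds shown here, the stereocentre at a saturated chain carbon is the first place in this set to be probed by a single change, and in this assay inverting it gives a 1.1-fold lower number from compound 1 to compound 4 (0.03 log units; within the scatter). For the compounds shown here, on this read-out, then, the configuration drawn at this carbon makes no difference that can be told from the usual spread of repeated measurements, something the earlier compounds could not show, as no two of them differed in just one place. The comparison is an unusually clean one, with no added or removed atoms to complicate the reading: the fact that compounds 1 and 4 differ only in the configuration as drawn

As far as these compounds go, this result speaks for one stereocentre only, so the other stereo elements of the molecule remain untested, and a tolerated flip at this carbon says nothing about how they would behave. The compounds shown also leave open what would happen if the atoms themselves were changed, for instance if an amine or a carboxylic acid replaced one of the phenol hydroxyl groups, and whether such a swap would move the number in this assay beyond the scatter.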